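A few compounds are considered here, and "the series" means these few. Any claim that something is new, unique, unknown or untested is made for them only; others in the source may bear on it.

Compound 2 `O=C1C=CC(OCC(F)(F)F)N1c1ccccc1` gives the highest number of the three measured, 24600 nM in a functional assay on K562 cells (Homo sapiens) for inhibition; on this read-out lower numbers stand for stronger inhibition and higher numbers for weaker inhibition. Compound 3 `O=C1C=CC(OCC(F)(F)F)N1c1ccccc1F` gives 12000 nM in this assay, and compound 1 `CC(C)NC1CC(=O)N(c2ccc(F)c(Cl)c2)C1OCC(F)(F)F`, built on a different core, gives 10500 nM. Compound 4 `O=C1C=CC(OCC(F)(F)F)N1c1ccc(Br)cc1` has not yet been measured; it differs from compound 2 by bromo in place of hydrogen on an aromatic carbon. Within the data shown here, the one measured step that bears on this is a 2.1-fold lower number from compound 2 to compound 3 (0.31 log units; beyond the scatter), a halogen entering the same ring, though at a different place. A step of about that size, again toward stronger inhibition, is therefore expected here, as a 2.1-fold lower number from compound 2 to compound 4 (0.31 log units; beyond the scatter). Compound 4 is accordingly estimated at 12000 nM, with a range from 4000 nM to 35000 nM in this assay.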

Compound 4, half-maximal inhibitory concentration: 3270 nM
Estimate against measurement, compound 4: 3.7-fold (0.56 log units) above, outside the stated range (below it).
By their numbers in this assay, from the lowest: compound 4; then compounds 1 and 3 (each within the scatter of the next); then compound 2.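

In this assay bromo on an aromatic carbon, para to a large group, brings a 7.5-fold lower number from compound 2 to compound 4 (0.88 log units; beyond the scatter) and this outruns a 2.1-fold lower number from compound 2 to compound 3 (0.31 log units; beyond the scatter) from the fluoro change. A halogen on this ring can therefore strengthen inhibition far more than the fluoro step alone showed. Those two steps differ in both the halogen and its place, so they cannot separate the two.

From the compounds shown here alone, whether bromine itself matters stays open, and chloro or methoxy at this same place would test that. No measurement at hand gives a reason for the size of this step.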